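Methylsulfonyl moved on the sulfonyl aryl ring

The source may report more compounds than this note shows. Statements on the series, on what has been measured and on what is new or still open speak of the compounds shown alone.

Compound 1 `CCOc1cc(C(Nc2ccc3cnccc3c2)C(=O)NS(=O)(=O)c2ccccc2)ccc1OC(C)C` carries an unsubstituted phenyl on the sulfonyl sulfur; in an assay on isolated protein for inhibition of Trypsin (Homo sapiens) (a lower number here means a stronger inhibitor, a higher number a weaker inhibitor), compound 1 gives only a limit of > 5000 nM. Compound 2 `CCOc1cc(C(Nc2ccc3cnccc3c2)C(=O)NS(=O)(=O)c2ccccc2S(C)(=O)=O)ccc1OC(C)C` adds a methylsulfonyl on that ring, and in this assay compound 2 likewise gives only a limit of > 5000 nM. The step that the two limits leave unreadable from compound 1 to compound 2 therefore has no readable size, since both ends sit at the limit of > 5000 nM in this assay, at which 2 of the 2 values shown sit. Compound 2 thus stands at the weak edge of what this assay can report, without a number of its own.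

Compound 3 `CCOc1cc(C(Nc2ccc3cnccc3c2)C(=O)NS(=O)(=O)c2cccc(S(C)(=O)=O)c2)ccc1OC(C)C` differs from compound 2 only in where the methylsulfonyl sits: 3-(methylsulfonyl)phenyl in place of 2-(methylsulfonyl)phenyl on a sulfonyl sulfur. Among the compounds with values here, no measured step bears directly on this change; the single step at hand, from compound 1 to compound 2, shows only that introducing the methylsulfonyl did not bring the value inside the measurable window. Moving that group is expected to leave compound 3 weak as well, so the step that the limit leaves unreadable from compound 2 to compound 3 is expected to stay within the scatter. For compound 3 the estimate in this assay is 12000 nM, with a range from 4000 nM to 60000 nM, most probably reported once more as a limit.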

Compound 3, inhibition constant: > 5000 nM
Compound 3 was reported as a limit (the forecaster's own chance of this, stated with the estimate: 85%); the middle value is on the limit's open side.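

Compound 3 is again reported only as a limit in this assay, so no step among compound 1, compound 2 and compound 3 can be read: the limit of > 5000 nM in this assay, at which 3 of the 3 values shown sit.

The compounds shown leave open how weak each one actually is in this assay, and whether 2-(methylsulfonyl)phenyl, 3-(methylsulfonyl)phenyl and the unsubstituted phenyl differ at all.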